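Hydrazone series: bromo for hydroxy on the benzoyl ring

A few compounds are considered here, and "the series" means these few. Any claim that something is new, unique, unknown or untested is made for them only; others in the source may bear on it.

Three compounds of the shared core have been run in an ADME assay on cells (Homo sapiens) for antiproliferative activity, read by MTT assay; a lower number here means a stronger inhibitor, a higher number a weaker inhibitor. Compound 1 `Nc1ccc(C(=O)N/N=C/c2ccccn2)cc1` gives only a limit, > 80000 nM, and this is the point at which one of the three results sits (the limit of > 80000 nM in this assay, at which 1 of the 3 values shown sits). Compound 2 `C/C(=N\NC(=O)c1ccc(O)cc1)c1cnccn1` gives 16800 nM in this assay, which is the higher of the two numbers reported. Compound 3 `O=C(NN=C(c1ccccn1)c1ccccn1)c1ccncc1` gives 830 nM in this assay, so compound 2 stands well behind compound 3, by a gap beyond the usual scatter.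

The next compound, compound 4 `C/C(=N\NC(=O)c1ccc(Br)cc1)c1cnccn1`, is compound 2 with one substituent exchanged: bromo in place of hydroxy on an aromatic carbon. Among the measured compounds shown here, the exchange removes a hydrogen-bond donor and an acceptor, and no measured pair isolates this kind of change, so there is no direct precedent to lean on.

The expectation is a modest gain in this assay, though one that may not clear the scatter. The estimated step from compound 2 to compound 4 is a 2.1-fold lower number from compound 2 to compound 4 (0.32 log units; beyond the scatter). Compound 4 is therefore expected to give about 8000 nM in this assay, with a plausible range from 2500 nM to 30000 nM.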

Compound 4, half-maximal inhibitory concentration: 1220 nM
For compound 4 the middle estimate is 6.6-fold (0.82 log units) above the measured one, outside the stated range (below it).
By their numbers in this assay, from the lowest: compounds 3 and 4 (each within the scatter of the next); then compound 2. At a limit, above all of these: compound 1.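

Notes on the position: on this aromatic carbon, para to a large group, bromo in place of hydroxy gives a 14-fold lower number from compound 2 to compound 4 (1.14 log units; beyond the scatter) in this assay and is the first one-place pair in the series. The position therefore responds strongly to the group it carries, and hydroxy, with its hydrogen-bond donor and acceptor, is not required here for a low number in this pair. Among the compounds shown here, nothing measured so far accounts for the size of this step, and the single pair cannot separate the departure of hydroxy from the arrival of bromo.

Still open, going by these compounds, is whether the gain belongs to bromo itself or to the absence of hydroxy, and a plain hydrogen, chloro, methoxy or a carboxylic acid at the same place would help to tell these apart. Also open, on these data alone, is whether the exchange carries the same weight outside this pair, since a single step on one scaffold says nothing about other members.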